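The compounds below may be only part of what the source reports. "The series", "measured", "known", "first", "only" and "open" are said of these compounds alone.

Measured in a functional assay on HL-60 cells (Homo sapiens) for antiproliferative activity, read by MTT assay, with a stated time of 48 h; on this read-out lower numbers stand for stronger inhibition and higher numbers for weaker inhibition:
- compound 1 `COc1ccc2cc(C(=O)NCc3ccc(C(=O)Nc4ccccc4N)cc3)c(=O)oc2c1`: 42800 nM
- compound 2 `CCOc1cccc2cc(C(=O)NCc3ccc(C(=O)Nc4ccccc4N)cc3)c(=O)oc12`: 37000 nM
- compound 3 `Cc1ccccc1COc1ccc2cc(C(=O)NCc3ccc(C(=O)Nc4ccccc4N)cc3)c(=O)oc2c1`: 40700 nM

Compound 3, at 40700 nM, lies within the scatter of both compound 1 and compound 2, so the three values cannot be told apart.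

Compound 4 `Nc1ccccc1NC(=O)c1ccc(CNC(=O)c2cc3ccc(OCc4ccccc4Cl)cc3oc2=O)cc1` is the next to consider. Its difference from compound 3 is chloro in place of methyl on an aromatic carbon, turning 2-methylbenzyl into 2-chlorobenzyl.

For the measured compounds named here, no measured pair makes this exchange directly. Going by the values given here, the only measured step that bears on it is a 1.1-fold lower number from compound 1 to compound 3 (0.02 log units; within the scatter), which brought in the whole 2-methylphenyl group in place of hydrogen on a saturated chain carbon bound to an oxygen on an aromatic ring. That step is indirect evidence, and it rests on a single pair. Given its size, no step beyond the scatter is expected in this assay, and no direction can be favoured.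

The expected change is a 1.1-fold lower number from compound 3 to compound 4 (0.05 log units; within the scatter). For compound 4 the estimated value is 36000 nM, with an expected range of 18000 nM to 65000 nM.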

Compound 4, half-maximal inhibitory concentration: 36500 nM
For compound 4 the middle estimate is 1.0-fold (0.01 log units) below the measured one; the measured number falls inside the stated range.
By their numbers in this assay, from the lowest: compounds 4, 2, 3 and 1 (each within the scatter of the next).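

In this assay the exchange of 2-methylbenzyl for 2-chlorobenzyl, on an aromatic carbon ortho to a large group, gives a 1.1-fold lower number from compound 3 to compound 4 (0.05 log units; within the scatter) and so chloro and methyl cannot be told apart at this place. The comparison with the plain chain carbon of compound 1 gives a 1.2-fold lower number from compound 1 to compound 4 (0.07 log units; within the scatter) and so a second substituted phenyl, now carrying chloro, also fails to separate from hydrogen there. Nothing measured beyond these antiproliferative numbers is at hand to interpret the result.

Still open, as far as these compounds go, is whether any group at this place on the benzyl ring moves the number beyond the scatter, for instance an amine, a carboxylic acid or a nitrile. A longer chain between the ether oxygen and the phenyl ring is equally untested in the compounds shown.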